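The compounds below may be only part of what the source reports. "The series", "measured", "known", "first", "only" and "open" are said of these compounds alone.

Measured compounds:
Compound 1, `O=c1c2ccccc2nc(CO[N+](=O)[O-])n1NS(=O)(=O)c1ccccc1`, gives 11.6%.
Compound 2, `Cc1nc2ccccc2c(=O)n1NS(=O)(=O)c1ccccc1`, gives 22.2%.
Compound 3, `Cc1nc2ccccc2c(=O)n1NC(=O)NC(C)(C)C`, gives 29.8%.

All three compounds were tested in a functional assay on the whole organism (strain Sprague-Dawley) for inhibition, with Rattus norvegicus as the target, read by paw edema, with stated times of 30 min and 2 h, at a dose of 80 mg/kg by the oral route; on this read-out lower numbers stand for less inhibition and higher numbers for more inhibition at the one dose given (going by the name of the read-out). Compound 2 and compound 1 differ in one place only: nitrooxy in place of hydrogen on a saturated chain carbon bound to an aromatic carbon. This change produced a step of a number 10.6 percentage points lower from compound 2 to compound 1 (beyond the scatter). Compound 3 carries a different core from compound 2; the difference between the two cores is not broken down here. Compound 3 gives the highest of the three numbers, but its gap to compound 2 lies within the usual scatter, so no order between the two is claimed; its gap to compound 1 lies beyond it.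

Compound 4, `CC(C)(C)NC(=O)Nn1c(CO[N+](=O)[O-])nc2ccccc2c1=O`, is not yet measured in this assay. It stands to compound 3 as compound 1 stands to compound 2: nitrooxy in place of hydrogen on a saturated chain carbon bound to an aromatic carbon. The place of the change is the same in both pairs, so the two changes are the same change, applied once to each core.

For the measured compounds named here, since the only precedent for this change is the step from compound 2 to compound 1, the expectation for compound 4 rests on that single step, with the caveat that the core is different and the change has been seen only once. Compound 4 is therefore expected to sit lower than compound 3 by about a number 10.8 percentage points lower from compound 3 to compound 4 (beyond the scatter), because of a number 10.6 percentage points lower from compound 2 to compound 1 (beyond the scatter). Compound 4 is estimated at 19%, with a likely range from 8% to 30%.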

Compound 4, a percentage reported as inhibition, in the whole organism at one dose (the size of the read-out at that dose, not a potency): 14.1%
Compound 4: middle estimate off by 4.9 percentage points, on the high side; the range from low to high includes it.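

In this assay the change gave a number 15.7 percentage points lower from compound 3 to compound 4 (beyond the scatter) and so ran in the same direction on the second core as on the first. As far as two steps can tell, its size also carried over from one core to the other: the same change on two cores in this assay, a number 10.6 percentage points lower (beyond the scatter) from compound 2 to compound 1 and a number 15.7 percentage points lower (beyond the scatter) from compound 3 to compound 4, 5.1 percentage points apart, within the scatter of two such steps. For the compounds shown here, this shows only that on the core of compound 2 and the core of compound 3 the nitrooxy group in place of hydrogen lowers the number at the one oral dose given; with just two pairs behind it, it does not show that the same would hold on any further core, and it does not explain why the number falls.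

The compounds shown leave open whether the lower number belongs to the nitrooxy group itself or would also follow from another group in the same place, such as a hydroxyl, an amine or a carboxylic acid on the saturated chain carbon bound to an aromatic carbon. They also leave open whether a longer chain carrying the nitrooxy group would give a step of similar size on these two cores.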